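Removing the ortho-chloro from the thiourea aryl of compound 2

The source may report more compounds than this note shows. Statements on the series, on what has been measured and on what is new or still open speak of the compounds shown alone.

Measured compounds:
compound 1, `NC(=O)c1c(NC(=O)c2ccccc2Cl)sc2c1CCN(C(=S)Nc1ccccc1)C2`, 15600 nM
compound 2, `NC(=O)c1c(NC(=O)c2ccccc2)sc2c1CCN(C(=S)Nc1ccccc1Cl)C2`, 11800 nM
compound 3, `NC(=O)c1c(NC(=O)c2ccncn2)sc2c1CCN(C(=S)Nc1ccccc1Cl)C2`, 28400 nM

In a functional assay on MKN-74 cells (Homo sapiens) for antiproliferative activity, with a stated time of 24 h (a higher number here means a weaker inhibitor, a lower number a stronger inhibitor), compound 2 gives 11800 nM, and compound 1 lies within the scatter of it; compound 3 stands higher, the step of a 2.4-fold higher number from compound 2 to compound 3 (0.38 log units; beyond the scatter) being beyond the scatter. Compound 4, `NC(=O)c1c(NC(=O)c2ccccc2)sc2c1CCN(C(=S)Nc1ccccc1)C2`, differs from compound 2 by hydrogen in place of chloro on an aromatic carbon. Among the compounds with values here, no measured step touches this position: the one step on record, from compound 2 to compound 3, changes the group on the carbonyl carbon instead, and compound 1 and compound 2 differ in two places at once. With nothing bearing directly on the change, compound 4 is expected to sit close to compound 2, the expected step of a 1.2-fold higher number from compound 2 to compound 4 (0.07 log units; within the scatter) lying within the scatter. The estimate for compound 4 is therefore 14000 nM, with a range of 6000 nM to 35000 nM.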

Compound 4, half-maximal inhibitory concentration: > 50000 nM
Compound 4: a limit, no number; the forecaster's own chance of this, stated with the estimate: 10%; at least 3.5-fold (0.55 log units) between middle value and limit.
By their numbers in this assay, from the lowest: compounds 2, 1 and 3 (each within the scatter of the next, the first and the last beyond it). At a limit, above all of these: compound 4.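

The value of compound 4 in this assay is a limit of the assay and not a number: the limit of > 50000 nM in this assay, at which 1 of the 4 values shown sits. Hydrogen in place of chloro on an aromatic carbon is therefore no neutral swap at the 2-chlorophenyl group, giving an at least 4.2-fold higher number from compound 2 to compound 4 (0.62 log units; beyond the scatter). The same exchange on the other aryl ring gives an at least 3.2-fold higher number from compound 1 to compound 4 (0.50 log units; beyond the scatter), so each single chloro counts in this series.

Going by these compounds, the true size of both steps stays open, since they rest on a limit. So does whether a fluoro, a methyl or an amine at that carbon would serve as the chloro does.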